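The source may report more compounds than this note shows. Statements on the series, on what has been measured and on what is new or still open speak of the compounds shown alone.

Working notes on the series. Compound 1 `COc1cc2c(Oc3ccc(NC(=O)c4cn(-c5ccccc5)nn4)cc3F)ccnc2cc1OCCCN1CCCC1` carries a phenyl on an aromatic nitrogen and a pyrrolidin-1-yl on a saturated chain carbon, three bonds along the chain from an oxygen on an aromatic ring. Going by the values given here, in a functional assay on MKN-45 cells (Homo sapiens) for cytotoxicity, read by MTT assay, with a stated time of 72 h (a lower number here means a stronger inhibitor, a higher number a weaker inhibitor), compound 1 gives 260 nM, the lowest of the two numbers measured so far. Among the compounds with values here, compound 2 `COc1cc2c(Oc3ccc(NC(=O)c4cn(-c5c(C)cccc5C)nn4)cc3F)ccnc2cc1OCCCN1CCCC1` differs from compound 1 only at the aromatic nitrogen, and in this assay compound 2 gives 3490 nM; the step of a 13-fold higher number from compound 1 to compound 2 (1.13 log units; beyond the scatter) is the single measured step in the set.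

Compound 3 `COc1cc2c(Oc3ccc(NC(=O)c4cn(-c5ccccc5)nn4)cc3F)ccnc2cc1OCCCN1CCCCC1` differs from compound 1 elsewhere: piperidin-1-yl in place of pyrrolidin-1-yl on a saturated chain carbon, three bonds along the chain from an oxygen on an aromatic ring. Within the data shown here, no measured step touches the chain; the step from compound 1 to compound 2 concerns the group on the aromatic nitrogen and gives no reading on a change of the saturated ring on the chain. With nothing in the set pointing in either direction, compound 3 is expected to show only a small step, a 1.2-fold higher number from compound 1 to compound 3 (0.06 log units; within the scatter), within the scatter. Compound 3 is therefore estimated at 300 nM, with a range from 100 nM to 900 nM.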

Compound 3, half-maximal inhibitory concentration: 100 nM
Compound 3: middle estimate off by 3.0-fold (0.48 log units), on the high side, and the stated range covers the measured number.
By their numbers in this assay, from the lowest: compound 3; then compound 1; then compound 2.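

The saturated ring on the chain is a position that registers in this assay: piperidin-1-yl in place of pyrrolidin-1-yl gives a 2.6-fold lower number from compound 1 to compound 3 (0.41 log units; beyond the scatter), so this end of the molecule is not silent, although the step is labelled modest. The change is confined to ring size, six-membered for five-membered, with hydrogen-bond donor and acceptor counts and net charge unchanged, and its direction is opposite to that of the change on the aromatic nitrogen, a 13-fold higher number from compound 1 to compound 2 (1.13 log units; beyond the scatter). No measurement in hand bears on the origin of the lower number with piperidin-1-yl.

Going by these compounds, two rings alone do not define a trend at this position, so it remains open whether morpholin-4-yl, 4-methylpiperazin-1-yl or an open dimethylamino group on the same chain would follow piperidin-1-yl or pyrrolidin-1-yl, and whether 2-(piperidin-1-yl)ethyl would keep the gain seen with 3-(piperidin-1-yl)propyl. Also open, on these data alone, is how piperidin-1-yl on the chain would read when combined with 2,6-dimethylphenyl on the aromatic nitrogen, or with a smaller group there such as 2-methylphenyl.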